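The compounds below may be only part of what the source reports. "The series", "measured", "known", "first", "only" and "open" are said of these compounds alone.

Three compounds that share a core and differ only in the aromatic group on it have been measured in a functional assay for activation of Alpha-1A adrenergic receptor (Homo sapiens), read by calcium flux; on this read-out higher numbers stand for an effect only at larger amounts of compound and lower numbers for an effect already at smaller amounts. Compound 1 `c1coc(-c2ccccc2NCC2=NCCN2)c1` gives 0.468 nM. Compound 2 `c1csc(-c2ccccc2NCC2=NCCN2)c1` gives 2.24 nM, and compound 3 `Cc1nc(-c2ccccc2NCC2=NCCN2)no1` gives 724 nM. Compound 3 therefore stands at the highest number of the three: the step of a 1500-fold higher number from compound 1 to compound 3 (3.19 log units; beyond the scatter) and the step of a 320-fold higher number from compound 2 to compound 3 (2.51 log units; beyond the scatter) are both large, whereas the step of a 4.8-fold higher number from compound 1 to compound 2 (0.68 log units; beyond the scatter) is modest. Compound 4 `Cc1ccc(-c2ccccc2NCC2=NCCN2)o1` has not yet been measured in this assay. It differs from compound 3 in one place: 5-methylfuran-2-yl in place of 5-methyl-1,2,4-oxadiazol-3-yl on an aromatic carbon. Going by the values given here, this change leads back toward the five-membered ring with a single hetero atom that compound 1 carries, so the steps that bear on it are those from compound 1 and from compound 2 to compound 3, both large and both toward higher numbers; read in reverse, they point to a large move toward lower numbers. Among the compounds with values here, no measured step speaks to the added methyl on the furan, so the range is taken wide rather than shifted. Compound 4 is thus expected to show a step of a 720-fold lower number from compound 3 to compound 4 (2.86 log units; beyond the scatter) in this assay. The value of compound 4 is estimated at 1 nM, within a range from 0.2 nM to 6 nM.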

Compound 4, half-maximal effective concentration: 2.69 nM
Beside the measured number, compound 4's estimate is 2.7-fold (0.43 log units) below it, within the range that was stated.
By their numbers in this assay, from the lowest: compound 1; then compounds 2 and 4 (each within the scatter of the next); then compound 3.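

In this assay, going by these compounds alone, 5-methylfuran-2-yl in place of 5-methyl-1,2,4-oxadiazol-3-yl on this aromatic carbon gives a 270-fold lower number from compound 3 to compound 4 (2.43 log units; beyond the scatter), and as both groups carry the methyl, this step ties the large change to the ring itself, which the earlier steps, all from rings without a methyl, could not separate from the methyl. The methyl alone, added to the furan, gives a 5.7-fold higher number from compound 1 to compound 4 (0.76 log units; beyond the scatter), a modest step far smaller than the ring exchange, while 5-methylfuran-2-yl in place of thiophen-2-yl gives a 1.2-fold higher number from compound 2 to compound 4 (0.08 log units; within the scatter), so these two groups cannot be told apart in this assay. Nothing at hand explains why the rings differ so widely on this read-out.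

The compounds shown leave open whether a group larger than methyl on the furan, such as ethyl or methoxy, or an amine there, would keep numbers this low. They also leave open how a methyl on the thiophene would read, and whether a six-membered ring such as phenyl or pyridine on this aromatic carbon would fall with the furans or with the oxadiazole.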